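The source may hold more compounds than are shown below. What is called first, only, known or untested is meant among the compounds shown, and "the series" means these compounds.

Working notes on a small series assessed in an ADME assay on BHK cells (Mesocricetus auratus) for cytotoxicity, read by MTT assay, with a stated time of 96 h; a higher number here means that more compound is tolerated, a lower number that less compound is tolerated.

Going by the values given here, compound 1 `COc1ccc(-c2nc3cc(Cl)c(Cl)cc3[nH]2)cc1` is the only member with a number in this assay: compound 1 gives 18000 nM. Compound 2 `CC(=O)Nc1ccc(-c2nc3cc([N+](=O)[O-])ccc3[nH]2)cc1` reaches only a limit of the assay in this assay, as compound 2 gives > 100000 nM. Compound 3 `CC(=O)Nc1ccc(-c2nc3ccccc3[nH]2)cc1` likewise gives a limit in this assay, compound 3 giving > 100000 nM. The difference between the core of compound 1 and the core of compound 3 is not broken down here.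

Compound 2 arises from compound 3 by one change, (nitro in place of hydrogen on an aromatic carbon). The step that the two limits leave unreadable from compound 3 to compound 2 cannot be read because of the limit of > 100000 nM in this assay, at which 2 of the 3 values shown sit.

Compound 4 `COc1ccc(-c2nc3cc(Cl)c(Cl)cc3[nH]2)c([N+](=O)[O-])c1`, not yet measured in this assay, arises from compound 1 by the same kind of change, (nitro in place of hydrogen on an aromatic carbon). The places differ: in compound 2 the nitro sits on a six-membered aromatic ring of carbon only, part of a fused or bridged system of two rings, meta to a fused ring and para to a fused ring, whereas in compound 4 it sits on a six-membered aromatic ring of carbon only, ortho to a large group and meta to a methoxy group. Among the compounds with values here, the one measured instance of this kind of change gives no readable size, so there is no basis for expecting movement in either direction from compound 1.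

For compound 4 the step of a 1.1-fold higher number from compound 1 to compound 4 (0.05 log units; within the scatter) is therefore expected to be small, resting on compound 1 at 18000 nM and on the unreadable step from compound 3 to compound 2. The expected value for compound 4 in this assay is 20000 nM, with the range 7000 nM to 60000 nM estimated to hold most repeat measurements.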

Compound 4, half-maximal cytotoxic concentration: 80000 nM
Compound 4: the middle estimate sits 4.0-fold (0.60 log units) below what was measured, outside the stated range (above it).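

In this assay, nitro in place of hydrogen on an aromatic carbon gives a 4.4-fold higher number from compound 1 to compound 4 (0.65 log units; beyond the scatter), so on the core of compound 1, with the nitro ortho to a large group and meta to a methoxy group, more compound is tolerated after the change. Going by these compounds alone, this is the only readable instance of the change, and it does not show that the shift carries to another core, since the nitro sits in a different place in compound 2, and the step from compound 3 to compound 2 cannot be read. That step stays unreadable because compound 3 and compound 2 both stand at a limit of the assay, which hides any size or direction of change between them: the limit of > 100000 nM in this assay, at which 2 of the 4 values shown sit.

On these data alone, it remains open whether the higher number in compound 4 depends on the nitro itself or would also appear with another group at that place, such as an amine or a carboxylic acid. Also open is how the chloro groups and the methoxy group each bear on the read-out, as the compounds shown offer no pair that differs in only one of these places.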